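The compounds below may be only part of what the source reports. "The series", "measured", "known", "first", "only" and "open" are said of these compounds alone.

Compound 1 `CCCCCCCCCCCCNc1nc(SCc2ccc(C(F)(F)F)cc2)nc2ccccc12` and compound 2 `CCCCCCCCCCCCCCNc1nc(SCc2ccc(C(F)(F)F)cc2)nc2ccccc12` carry alkyl chains on the ring nitrogen of the shared core, compound 3 `COc1ccccc1Nc1nc(SCc2ccc(C(F)(F)F)cc2)nc2ccccc12` an aryl group. In a functional assay on MDA-MB-231 cells (Homo sapiens) for cytotoxicity, read by MTT assay, with a stated time of 72 h (on this read-out higher numbers stand for weaker inhibition and lower numbers for stronger inhibition), compound 1 gives > 50000 nM, a limit of the assay. Compound 2 gives > 50000 nM, likewise a limit. Compound 3 gives > 50000 nM, also a limit, so it stands where every value of the set sits: the limit of > 50000 nM in this assay, at which 3 of the 3 values shown sit. Compound 4 `Fc1ccc(Nc2nc(SCc3ccc(C(F)(F)F)cc3)nc3ccccc23)cc1` differs from compound 3 in one place: 4-fluorophenyl in place of 2-methoxyphenyl on a nitrogen on an aromatic ring. For the measured compounds named here, the only measured step, a step that the two limits leave unreadable from compound 1 to compound 2, is unreadable and concerns a chain, not an aryl group, so no size can be drawn from it for this exchange. The step from compound 3 to compound 4 is therefore expected to be a step that the limit leaves unreadable from compound 3 to compound 4. Compound 4 is expected to give 60000 nM, range 20000 nM to 200000 nM, most likely again as a limit.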

Compound 4, half-maximal inhibitory concentration: 15000 nM
Beside the measured number, compound 4's estimate is 4.0-fold (0.60 log units) above it; measured number outside the range, below it.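

On the nitrogen of the shared core, 4-fluorophenyl in place of 2-methoxyphenyl gives a step that can be read in this assay: an at least 3.3-fold lower number from compound 3 to compound 4 (0.52 log units; beyond the scatter). The aryl group at this position therefore matters to the read-out, which the step between the two alkyl chains, unreadable between limits, could not show. Compound 4 is the only compound shown with a number, the others remaining limits: the limit of > 50000 nM in this assay, at which 3 of the 4 values shown sit.

Still open, from the compounds shown here alone, is whether the step follows the loss of the methoxy group or the arrival of the fluorine. Unsubstituted phenyl, 2-fluorophenyl and 4-methoxyphenyl on the same nitrogen would separate the two.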